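Removing a Methyl from a Weak Cytotoxic Amide

A few compounds are considered here, and "the series" means these few. Any claim that something is new, unique, unknown or untested is made for them only; others in the source may bear on it.

Among the compounds with values here, compound 3, with the structure `Cc1ccc(NC(=O)c2cccc(/C=C3\CC(=O)N(c4ccccc4)C3=O)c2)cc1C`, is one of three compounds measured in an ADME assay on SW480 cells (Homo sapiens) for cytotoxicity, read by MTT assay, with a stated time of 72 h; a higher number here means a weaker inhibitor, a lower number a stronger inhibitor. In this assay compound 3 gives only a limit, > 100000 nM, and no number. Of its two neighbours, compound 1 `CCOc1ccc(NC(=O)c2cccc(/C=C3\CC(=O)N(c4ccccc4)C3=O)c2)cc1` gives 91500 nM, and compound 2 `CCCCCN1C(=O)C/C(=C\c2cccc(C(=O)Nc3cccc(CC)c3)c2)C1=O` gives 83300 nM. Within the data shown here, the one step between measured compounds, an at least 1.0-fold higher number from compound 1 to compound 3 (0.03 log units; that floor lies within the scatter), lies within the scatter and only marks that compound 3 sits at the limit of > 100000 nM in this assay, at which 1 of the 3 values shown sits.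

Compound 4, with the structure `Cc1ccc(NC(=O)c2cccc(/C=C3\CC(=O)N(c4ccccc4)C3=O)c2)cc1`, is not yet measured. It differs from compound 3 by hydrogen in place of methyl on an aromatic carbon, so the change is 3,4-dimethylphenyl to 4-methylphenyl on the amide-type nitrogen. Among the measured compounds shown here, no measured step shows what removing a methyl from this ring does. All three measured values sit close to or at the limit, so the expected step of a number no higher from compound 3 to compound 4 (the limit leaves the size open) is none beyond the scatter. Compound 4 is therefore estimated at 100000 nM, with a range from 50000 nM to 200000 nM, and a good chance that only a limit is reported again.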

Compound 4, half-maximal inhibitory concentration: > 100000 nM
Compound 4 gave a limit, no number; the forecaster's own chance of this, stated with the estimate: 55%; the middle value sits exactly at the limit.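

In this assay compound 4 gives > 100000 nM, which is a limit of the assay and not a number. Compound 3 carries the same limit, so the effect of hydrogen in place of methyl on this ring cannot be read, and the limit now recurs in the series: the limit of > 100000 nM in this assay, at which 2 of the 4 values shown sit. Methyl in place of ethoxy on an aromatic carbon gives an at least 1.0-fold higher number from compound 1 to compound 4 (0.03 log units; that floor lies within the scatter), so that change shows only a floor and no measured size.

On these data alone, what an amine or a carboxylic acid on this same ring would do remains open. As far as these compounds go, whether the methyl matters at all also remains open, and answering that would take compounds whose values fall clear of the limit.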